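Compound 2 to compound 3: one stereocentre inverted

The source may report more compounds than this note shows. Statements on the series, on what has been measured and on what is new or still open speak of the compounds shown alone.

Measured so far:
- compound 1, `OC(CCn1nc2c(Br)c(Br)c(Br)c(Br)c2n1)c1cccc(Cl)c1`, in a functional assay on CCRF-CEM cells (Homo sapiens) for antiproliferative activity, read by MTT assay, with a stated time of 24 h, tested at 12.5 uM (a lower number here means a stronger effect, a higher number a weaker effect of the compound at the concentration tested), gives 110%
- compound 2, `C[C@@H](O)CCn1nc2c(Br)c(Br)c(Br)c(Br)c2n1`, in this assay gives 88%

Of the two numbers measured, compound 2 holds the lower one in this assay; the nearest, compound 1, stands higher by a gap beyond the usual scatter, and the two compounds also differ at several places in the chain. Compound 3, `C[C@H](O)CCn1nc2c(Br)c(Br)c(Br)c(Br)c2n1`, has not yet been measured in this assay.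

the two compounds have the same atoms and bonds and differ only in configuration as drawn: 1 of 1 stereo elements differ; a stereocentre at a saturated chain carbon is drawn R in compound 2 and S in compound 3

For the measured compounds named here, no step between two measured compounds that differ in only one place is known, so nothing in the data shows how large an effect a change of configuration alone has in this assay. The step expected from compound 2 to compound 3 is therefore small, a number 2 percentage points higher from compound 2 to compound 3 (within the scatter), and not beyond the scatter in either direction. Compound 3 is expected to give about 90% in this assay, in a range from 72% to 108%.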

Compound 3, a percentage reported as activity, at one concentration (the size of the read-out at that concentration, not a potency): 126%
For compound 3 the middle estimate is 36 percentage points below the measured one, outside the stated range (above it).
By their numbers in this assay, from the lowest: compound 2; then compound 1; then compound 3.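

In this assay, inverting the one stereocentre at the saturated chain carbon, from R to S, gives a number 38 percentage points higher from compound 2 to compound 3 (beyond the scatter). A higher number means a weaker effect at the concentration tested, so the S form is the weaker of this pair. The earlier comparison could not show this, as compound 1 and compound 2 differ at several places, whereas this step can be put down to the configuration at this carbon alone: the fact that compounds 2 and 3 differ only in the configuration as drawn

The compounds shown leave open whether the configuration at this carbon would matter as much with an amine in place of the hydroxyl, or with a longer chain. They also leave open how far apart the two forms would stand at other concentrations, as this read-out gives the size of an effect at one concentration and not a potency.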